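Acetylating an Aromatic Amine in Arylquinoline Antiproliferatives

The source may report more compounds than this note shows. Statements on the series, on what has been measured and on what is new or still open speak of the compounds shown alone.

Compound 1 `Cc1ccc(C(=O)Nc2cccc(-c3ccnc4c(N)cccc34)c2)cc1C` and compound 2 `CC(=O)Nc1cccc2c(-c3cccc(NC(=O)c4ccc(C)c(C)c4)c3)ccnc12` share a core carrying an amino group, and compound 2 adds an acetyl to it: acetyl in place of hydrogen on a nitrogen on an aromatic ring. In a functional assay on A375P cells (Homo sapiens) for antiproliferative activity, read by MTT assay, with a stated time of 48 h (a lower number here means a stronger inhibitor, a higher number a weaker inhibitor), compound 1 reaches only the limit > 20000 nM. Compound 2 likewise reaches only the limit > 20000 nM in this assay. The step that the two limits leave unreadable from compound 1 to compound 2 therefore cannot be sized. Compound 3 `Cc1ccc(NC(=O)c2ccc(Cl)c(C(F)(F)F)c2)cc1-c1ccnc2c(N)cccc12` differs from compound 1 in more than one place; how the two cores differ is not broken down here. In this assay, among the compounds with values here, compound 3 gives 3300 nM, the only value shown as a number. Compound 4 `CC(=O)Nc1cccc2c(-c3cc(NC(=O)c4ccc(Cl)c(C(F)(F)F)c4)ccc3C)ccnc12` is compound 3 carrying the same change: acetyl in place of hydrogen on a nitrogen on an aromatic ring. The step from compound 3 to compound 4 is expected to be a 2.1-fold higher number from compound 3 to compound 4 (0.33 log units; beyond the scatter), a moderate weakening, an expectation that rests on the measured pair, where the acetylated compound 2 stayed at the limit of > 20000 nM in this assay, at which 2 of the 3 values shown sit, and the unacetylated compound 1 gave no number either, so nothing shows the acetyl helping. Compound 4 is thus expected to give about 7000 nM, between 2500 nM and 20000 nM.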

Compound 4, half-maximal inhibitory concentration: 12200 nM
Estimate against measurement, compound 4: 1.7-fold (0.24 log units) below; measured number inside the range.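

On the core of compound 3, amino to acetamido gives a 3.7-fold higher number from compound 3 to compound 4 (0.57 log units; beyond the scatter) in this assay, so on this core the change weakens the compound. The same change on the core of compound 1 cannot be sized, because both values of that pair are limits of the assay and not numbers: the limit of > 20000 nM in this assay, at which 2 of the 4 values shown sit. The series therefore holds a single sized step, which shows no gain from the acetyl but cannot show whether the same loss would appear on a different core.

On these data alone, what remains open is whether another group on that nitrogen, such as a methyl or a propanoyl, would keep the activity of compound 3 or lose it as the acetyl does. Also open, as far as these compounds go, is how large the step from amino to acetamido would be on any further core in which both partners give a readable number.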